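Swapping an Aminochloropyridine Amide for a Chlorophenyl Amide

This account rests on a few compounds, and the source may have more. Where it says the series, first, only, none or still open, it means among the compounds named here.

Compound 2 `CC[C@H]1CN(c2ncc(-c3ncc[nH]3)nc2C)[C@H](C)CN1C1CCN(C(=O)c2ccc(Cl)nc2N)CC1` gives 1.8 nM in an assay on isolated protein for binding affinity to C-X-C chemokine receptor type 3 (Homo sapiens) (a lower number here means a stronger inhibitor, a higher number a weaker inhibitor), the lowest of the two values known here. Compound 1 `CC[C@H]1CN(c2ncc(C#N)cc2Cl)CCN1C1CCN(Cc2ccc(Cl)cc2F)CC1` gives 50.5 nM in this assay, a clearly weaker result that lies well outside the usual scatter. Compound 3 `CC[C@H]1CN(c2ncc(-c3ncc[nH]3)nc2C)[C@H](C)CN1C1CCN(C(=O)c2ccc(Cl)cc2)CC1` differs from compound 2 in a single place: 4-chlorophenyl in place of 2-amino-6-chloropyridin-3-yl on a carbonyl carbon. Among the measured compounds shown here, no measured pair shows this exact swap, so the step from compound 2 to compound 3 is expected to weaken binding somewhat, probably beyond the usual scatter, by about a 3.9-fold higher number from compound 2 to compound 3 (0.59 log units; beyond the scatter). For compound 3 the estimated value is 7 nM, with a likely range from 1.8 nM to 30 nM.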

Compound 3, half-maximal inhibitory concentration: 1.6 nM
Beside the measured number, compound 3's estimate is 4.4-fold (0.64 log units) above it; the measured number lies below the stated range.
By their numbers in this assay, from the lowest: compounds 3 and 2 (each within the scatter of the next); then compound 1.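

The swap on the carbonyl carbon gives a 1.1-fold lower number from compound 2 to compound 3 (0.05 log units; within the scatter) in this assay and so leaves binding effectively unchanged. At this position, 4-chlorophenyl, with 0 hydrogen-bond donors and 0 hydrogen-bond acceptors, serves as well as 2-amino-6-chloropyridin-3-yl, with its 1 donor and 2 acceptors. High affinity in this pair therefore does not depend on the amino group or the ring nitrogen.

Still open, as far as these compounds go, is how a plain phenyl without chlorine, or a carboxylic acid on the ring, would behave here. Nothing available explains why the two groups match.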